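Series notes: methylsulfanyl to benzylsulfanyl on two cores

The source may hold more compounds than are shown below. What is called first, only, known or untested is meant among the compounds shown, and "the series" means these compounds.

Measured compounds, all in a functional assay on KB cells (Homo sapiens) for antiproliferative activity; a lower number here means a stronger inhibitor, a higher number a weaker inhibitor:
Compound 1 `CSc1nc2c(C)nsc2n1[C@H]1C[C@H](O)[C@@H](CO)O1` gives > 100000 nM, a limit of the assay and not a number.
Compound 2 `Cc1nsc2c1nc(SCc1ccccc1)n2[C@H]1C[C@H](O)[C@@H](CO)O1` gives > 100000 nM, likewise a limit of the assay.
Going by the values given here, compound 3 `CSc1nc2sncc2n1[C@H]1C[C@H](O)[C@@H](CO)O1` gives 6000 nM, the only number in the set.

Compound 4 `OC[C@H]1O[C@@H](n2c(SCc3ccccc3)nc3sncc32)C[C@@H]1O` is not yet measured.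

The change from compound 1 to compound 2 is phenyl in place of hydrogen on a saturated chain carbon bound to a sulfur. Its step in this assay is a step that the two limits leave unreadable from compound 1 to compound 2; because of the limit of > 100000 nM in this assay, at which 2 of the 3 values shown sit, the pair says nothing about the direction or size of that change on this core.

Compound 4 carries the same change on the core of compound 3: phenyl in place of hydrogen on a saturated chain carbon bound to a sulfur. The two "place" descriptions are word for word the same, so this is the same change, not merely the same kind. The difference between the core of compound 1 and the core of compound 3 is not broken down here.

For compound 4 the expectation must rest on compound 3 alone, as the measured pair gives no readable step. The step from compound 3 to compound 4 in this assay is estimated as a 2.0-fold higher number from compound 3 to compound 4 (0.30 log units; within the scatter), taken as small in either direction, with compound 3 at 6000 nM as the only anchor. Compound 4 is therefore estimated at 12000 nM in this assay, within a range of 2000 nM to 70000 nM, with a real chance that it too returns only a limit.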

Compound 4, half-maximal inhibitory concentration: 3000 nM
Compound 4: middle estimate off by 4.0-fold (0.60 log units), on the high side; the range from low to high includes it.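

In this assay, methylsulfanyl to benzylsulfanyl on the core of compound 3 gives a 2.0-fold lower number from compound 3 to compound 4 (0.30 log units; within the scatter), so compound 3 and compound 4 cannot be told apart in this read-out, and on this core the added phenyl leaves activity measurable. The same change on the core of compound 1 cannot be read, because compound 1 and compound 2 both return a limit and not a number: the limit of > 100000 nM in this assay, at which 2 of the 4 values shown sit. The series therefore holds one readable pair and does not show whether the change carries from one core to the other; it shows neither that the two cores respond alike nor that they respond differently.

Still open, going by these compounds, is whether any other group on the saturated chain carbon bound to a sulfur would move the number beyond the scatter on the core of compound 3, for example a longer chain such as butyl, or a chain ending in an amine or a carboxylic acid. Also open, on these data alone, is whether any such group would bring the core of compound 1 off the limit and give a step that can be read on both cores.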